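Pyrazolylamino variations on a nitrile-bearing pyrrolopyrimidine core

The compounds below may be only part of what the source reports. "The series", "measured", "known", "first", "only" and "open" are said of these compounds alone.

Measured so far in an assay on isolated protein for binding affinity to Leucine-rich repeat serine/threonine-protein kinase 2 (Homo sapiens), read by TR-FRET and LanthaScreen, with a stated time of 2 h; a lower number here means a stronger inhibitor, a higher number a weaker inhibitor:
compound 1 `Cc1c(Nc2nc(N)c3c(C#N)c(N4CCC[C@H]4C)n(C)c3n2)cnn1C` gives 2 nM
compound 2 `C[C@@H]1CCCN1c1c(C#N)c2c(N)ncnc2n1C` gives 0.4 nM
compound 3 `Cc1n[nH]cc1Nc1nc(N)c2c(C#N)c(N3CCC[C@H]3C)n(C)c2n1` gives 1 nM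

Compound 3 holds the second highest of the three numbers in this assay; its nearest neighbour is compound 1, a 2.0-fold lower number from compound 1 to compound 3 (0.30 log units; within the scatter) lying within the scatter, while the step of a 2.5-fold higher number from compound 2 to compound 3 (0.40 log units; beyond the scatter) lies beyond it. Compound 4 `Cc1nn(C)cc1Nc1nc(N)c2c(C#N)c(N3CCC[C@H]3C)n(C)c2n1` differs from compound 3 by methyl in place of hydrogen on an aromatic nitrogen, on an aromatic nitrogen of a five-membered aromatic ring with 2 nitrogen. Among the measured compounds shown here, the only measured step touching this ring's methyl pattern is a 2.0-fold lower number from compound 1 to compound 3 (0.30 log units; within the scatter), within the scatter, so compound 4 is expected to sit close to compound 3, with no change at the digits printed from compound 3 to compound 4 (within the scatter) not beyond the scatter. Compound 4 is therefore estimated at 1 nM, in the range 0.4 nM to 2.5 nM.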

Compound 4, inhibition constant: 1 nM
For compound 4 middle estimate and measured number coincide at the digits printed, and the stated range covers the measured number.
By their numbers in this assay, from the lowest: compound 2; then compounds 3, 4 and 1 (each within the scatter of the next).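

In this assay, methyl in place of hydrogen on the aromatic nitrogen is accepted (no change at the digits printed from compound 3 to compound 4 (within the scatter)), so a hydrogen on that nitrogen is not required for this level of binding. The 1,3-dimethyl-1H-pyrazol-4-yl and 1,5-dimethyl-1H-pyrazol-4-yl patterns are not told apart (a 2.0-fold lower number from compound 1 to compound 4 (0.30 log units; within the scatter)). The (1,3-dimethyl-1H-pyrazol-4-yl)amino group in place of hydrogen still gives a weaker number (a 2.5-fold higher number from compound 2 to compound 4 (0.40 log units; beyond the scatter)).

As far as these compounds go, whether a longer chain on that nitrogen, such as 2-hydroxyethyl, or a morpholine-bearing chain would hold the number stays open. Nothing available explains these steps.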